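Para-halogen swap on a benzylidene semicarbazide series

The source may hold more compounds than are shown below. What is called first, only, known or untested is meant among the compounds shown, and "the series" means these compounds.

Of the compounds shown here, three share a core and have been tested in a functional assay on MKN-45 cells (Homo sapiens) for cytotoxicity, read by MTT assay, with a stated time of 72 h; a higher number here means a weaker inhibitor, a lower number a stronger inhibitor. Compound 1 `CN(C)CCn1cnnc1-c1cc(Oc2ccc(NC(=O)N/N=C/c3cc(C(C)(C)C)cc(C(C)(C)C)c3O)cc2F)ccn1` gives 3300 nM. Compound 2 `Cn1ncnc1-c1cc(Oc2ccc(NC(=O)N/N=C/c3ccccc3)cc2F)ccn1` reaches only the limit of the assay, > 100000 nM, a limit and not a number (the limit of > 100000 nM in this assay, at which 1 of the 3 values shown sits). Compound 3 `CN(C)CCn1cnnc1-c1cc(Oc2ccc(NC(=O)N/N=C/c3ccc(F)cc3)cc2F)ccn1` gives 1030 nM, which is the lowest of the two numbers shown; the nearest, compound 1, sits beyond the scatter above it. Within the data shown here, no pair of measured compounds differs in a single place, so no measured step is available.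

Compound 4 `CN(C)CCn1cnnc1-c1cc(Oc2ccc(NC(=O)N/N=C/c3ccc(Cl)cc3)cc2F)ccn1` differs from compound 3 by chloro in place of fluoro on an aromatic carbon, para to a large group. Nothing measured here speaks to the size or direction of such a change, so the step is expected to stay within the scatter or to favour compound 4 only slightly. The step from a 1.3-fold lower number from compound 3 to compound 4 (0.11 log units; within the scatter) is therefore expected to be small. In this assay compound 4 is estimated at 800 nM, within a range from 300 nM to 2500 nM.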

Compound 4, half-maximal inhibitory concentration: 570 nM
For compound 4 the middle estimate is 1.4-fold (0.15 log units) above the measured one; measured number inside the range.
By their numbers in this assay, from the lowest: compounds 4 and 3 (each within the scatter of the next); then compound 1. At a limit, above all of these: compound 2.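

In this assay, among these compounds, the exchange of 4-fluorophenyl for 4-chlorophenyl gives a 1.8-fold lower number from compound 3 to compound 4 (0.26 log units; within the scatter) and is the first single-place step that can be read. With one halogen exchanged for the other on an aromatic carbon, para to a large group, the read-out does not separate the two compounds, so this position accepts chloro as well as fluoro in this assay. Nothing measured here offers a reason for the size of this step.

On these data alone, whether the same position would accept a methoxy group, a nitrile or an amine in place of a halogen stays open. Among the compounds shown here, compound 2 stands at > 100000 nM, a limit and not a number, and it differs from compound 3 and compound 4 in more than one place, so no step to it can be read.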